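The source may hold more compounds than are shown below. What is called first, only, known or untested is meant among the compounds shown, and "the series" means these compounds.

Measured compounds, with their values in a functional assay on thoracic aorta (Rattus norvegicus, strain Wistar), with a stated time of 15 min; a lower number here means that less compound is needed, a higher number that more compound is needed for the effect:

compound 1, `CCOc1ccc(Br)cc1C(C)NC(=O)N(C)S(=O)(=O)c1ccc(Cl)cc1`: compound 1 gives 55700 nM
compound 2, `CCOc1ccc(F)cc1C(C)NC(=O)N(C)S(=O)(=O)c1ccccc1`: compound 2 gives 11500 nM
compound 3, `COc1ccc(F)cc1C(C)NC(=O)N(C)S(=O)(=O)c1ccc(Cl)cc1`: compound 3 gives 12600 nM

Compound 3 sits second highest of the three numbers. Its nearest neighbour is compound 2, whose number lies within the scatter of that of compound 3, so no order between the two can be read. Compound 1 stands furthest away, with a number higher than that of compound 3 beyond the scatter.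

Compound 4 is `CCOc1ccc(F)cc1C(C)NC(=O)N(C)S(=O)(=O)c1ccc(Cl)cc1`. Relative to compound 3 the change is methyl in place of hydrogen on a saturated chain carbon bound to an oxygen on an aromatic ring. Going by the values given here, no pair differing in this one place has been measured, so the step is not known from the series. Compound 2 already carries the ethoxy group and gives a number within the scatter of compound 3, so in this assay a step of no size beyond the scatter is expected from compound 3 to compound 4, a 1.1-fold lower number from compound 3 to compound 4 (0.02 log units; within the scatter). Compound 4 is therefore estimated at 12000 nM, within a range from 5000 nM to 30000 nM.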

Compound 4, half-maximal effective concentration: 24500 nM
The estimate for compound 4 lay 2.0-fold (0.31 log units) below the measured number; low and high end bracket the measured number.
By their numbers in this assay, from the lowest: compounds 2, 3 and 4 (each within the scatter of the next, the first and the last beyond it); then compound 1.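

In this assay the change from methoxy to ethoxy can now be read on its own: a 1.9-fold higher number from compound 3 to compound 4 (0.29 log units; within the scatter) stays short of a change that can be claimed at this position. On the ethoxy compounds, two aromatic changes do pass the scatter, both modestly: chloro in place of hydrogen gives a 2.1-fold higher number from compound 2 to compound 4 (0.33 log units; beyond the scatter) and fluoro in place of bromo gives a 2.3-fold lower number from compound 1 to compound 4 (0.36 log units; beyond the scatter) on an aromatic carbon. No measurement on hand bears on the reason for any of these steps.

Open, going by these compounds, is whether a longer chain than ethyl, or an amine in place of the ethoxy group, would move the number from that of compound 4 beyond the scatter.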